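A few compounds are considered here, and "the series" means these few. Any claim that something is new, unique, unknown or untested is made for them only; others in the source may bear on it.

Of the compounds shown here, three sharing one core have been tested in a functional assay on SW982 cells (Homo sapiens) for inhibition, read by MTT assay, with a stated time of 72 h (on this read-out higher numbers stand for weaker inhibition and lower numbers for stronger inhibition), so far. Compound 1 (`COc1cc(OC)c(OC)cc1/C=C/C(=O)c1ccc(-c2c[nH]cn2)cc1`) gives > 150000 nM in this test, which is a limit and not a number. Within the data shown here, compound 2 (`COc1cc(OC)c(OC)cc1/C=C/C(=O)c1ccc(O)cc1O`) gives 32400 nM as the only true number so far. Compound 3 (`COc1cc(OC)c(OC)cc1/C=C/C(=O)c1cc(O)ccc1O`) gives > 150000 nM as its reading, which is also a limit and not a number. Compound 3 therefore has no number of its own and stands at the limit of > 150000 nM in this assay, at which 2 of the 3 values shown sit, on the weak side of the data.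

Compound 4 (`COc1cc(OC)c(OC)cc1/C=C/C(=O)c1ccc(O)cc1`) differs from compound 3 in one place, with 4-hydroxyphenyl in place of 2,5-dihydroxyphenyl on a carbonyl carbon. Among the measured compounds shown here, only one measured step concerns these hydroxyphenyl groups, namely an at least 4.6-fold higher number from compound 2 to compound 3 (0.66 log units; beyond the scatter) on going to the 2,5-dihydroxyphenyl group. Compound 4 has a 4-hydroxyphenyl group, so by name it stands closer to the 2,4-dihydroxyphenyl group of compound 2, though a single step is thin support. The expected change is an at least 2.5-fold lower number from compound 3 to compound 4 (0.39 log units; beyond the scatter) in this assay and points toward a lower number, although the reading may well stay at the limit. The estimated value for compound 4 is 60000 nM (expected range 20000 nM to 150000 nM).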

Compound 4, half-maximal inhibitory concentration: 155000 nM
Estimate against measurement, compound 4: 2.6-fold (0.41 log units) below, outside the stated range (above it).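

In this assay, among these compounds, putting hydrogen in place of hydroxy on an aromatic carbon gives a 4.8-fold higher number from compound 2 to compound 4 (0.68 log units; beyond the scatter), and this is the first step on this ring with a true number at both ends. The 2,4-dihydroxyphenyl group of compound 2 therefore reads as stronger than the 4-hydroxyphenyl group of compound 4, so the added hydroxy matters on this read-out, although the numbers for both compounds remain high. Compound 1 and compound 3 each carry a limit and not a number, so their steps to compound 4 cannot be read, and the 2,5-dihydroxyphenyl group and the 1H-imidazol-4-yl group cannot be ranked against the 4-hydroxyphenyl group: the limit of > 150000 nM in this assay, at which 2 of the 4 values shown sit.

On these data alone, what a methoxy group, an amine or a carboxylic acid would do in place of the hydroxy of compound 4 on the same aromatic carbon remains open. Also open, as far as these compounds go, is whether any group on this ring can bring the shared core clearly below the reading of compound 2, which gives 32400 nM.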